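A few compounds are considered here, and "the series" means these few. Any claim that something is new, unique, unknown or untested is made for them only; others in the source may bear on it.

Measured compounds:
Compound 1, `C[C@@H]1C=NN(C(=O)C(C)(C)C)[C@@H]1c1ccccc1`, gives 6.5 in a physicochemical assay for lipophilicity, read by HPLC, measured as chromatographic lipophilicity, at pH 7.4; on this read-out higher numbers stand for higher lipophilicity and lower numbers for lower lipophilicity.
Compound 2, `O=C(C1CCN(C(=O)C(F)(F)F)CC1)N1N=CCC1c1ccccc1`, gives 4.9.
Compound 3, `CC(C)(C)C(=O)N1N=CCC1c1cccnc1`, gives 3.2.

On these three numbers compound 2 stands second highest. Compound 1 sits above it, with a gap that lies beyond the scatter of the measurement, and compound 3 sits below it, again by a gap beyond the scatter. Compound 2 thus occupies the middle of the small range that has been measured so far.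

The account now follows the step from compound 2 to compound 4, `O=C(c1cocn1)N1CCC(C(=O)N2N=CCC2c2ccccc2)CC1`, which has not yet been measured. The two structures differ in one place: 1,3-oxazol-4-yl in place of trifluoromethyl on a carbonyl carbon. Going by the values given here, no pair among the three measured compounds differs in only one place, so there is no measured step of any kind to lean on, and none that resembles this exchange of trifluoromethyl for 1,3-oxazol-4-yl on a carbonyl carbon.

The step is therefore expected from the structural change alone. In this assay it is expected to read a number 1.20 log units lower from compound 2 to compound 4 (beyond the scatter), a move downward that goes beyond the scatter. Compound 4 is accordingly expected to come out at 3.7, with a range from 2.9 to 4.5.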

Compound 4, distribution coefficient: 2.9
Beside the measured number, compound 4's estimate is 0.80 log units above it, and the stated range covers the measured number.
By their numbers in this assay, from the lowest: compounds 4 and 3 (each within the scatter of the next); then compound 2; then compound 1.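

In this assay, going by these compounds alone, the exchange of trifluoromethyl for 1,3-oxazol-4-yl on a carbonyl carbon gives a number 2.00 log units lower from compound 2 to compound 4 (beyond the scatter) and thus supplies the only measured step here in which just one place changes. The earlier compounds shown here held no such pair and so could say nothing about this position on its own, whereas this large step shows that the read-out responds strongly to the group held on this carbonyl carbon, with the rest of compound 2 left unchanged. No measurement shown here explains why the number moves this far, so the step stands as an observation without an assigned cause.

A single exchange cannot separate what the departure of trifluoromethyl contributes from what the arrival of 1,3-oxazol-4-yl contributes, and it cannot show whether the same exchange would give a step of similar size on a different core. It also leaves open where an ethyl chain, an amine or a carboxylic acid on this carbonyl carbon would read relative to compound 2 and compound 4.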